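Anilino Swap on a Glutarimide Core: A Predicted Step

This account rests on a few compounds, and the source may have more. Where it says the series, first, only, none or still open, it means among the compounds named here.

Of the compounds shown here, two share a glutarimide-bearing core and have been tested in an assay on FRT-Jurkat cells for inhibition of nuclear factor NF-kappa-B complex (Homo sapiens), read by flow cytometry, with a stated time of 24 h, tested at 10 uM; on this read-out higher numbers stand for more inhibition at the one concentration tested (going by the name of the read-out) and lower numbers for less inhibition. Compound 1 `O=C1CCC(N2C(=O)c3cccc(Nc4ccccc4)c3C2=O)C(=O)N1` gives 4% in this assay. Compound 2 `CN(c1ccccc1)c1ccc2c(c1)C(=O)N(C1CCC(=O)NC1=O)C2=O` gives -2% in this assay. The two figures lie within the usual scatter of each other, so neither compound is separated from the other on this read-out, and both sit near the zero line, where little inhibition is seen at the single concentration tested.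

Compound 3 `COc1ccc(Nc2ccc3c(c2)C(=O)N(C2CCC(=O)NC2=O)C3=O)cc1` has not yet been measured in this assay. Its difference from compound 2 is a single exchange: (4-methoxyphenyl)amino in place of methyl(phenyl)amino on an aromatic carbon. Going by the values given here, no step between measured compounds bears on this exchange, so no measured precedent for its size exists in this set.

Given that compound 1 gives 4% and compound 2 gives -2% in this assay, the expectation for compound 3 is a step of about a number 5 percentage points higher from compound 2 to compound 3 (within the scatter), which is no change beyond the scatter. Compound 3 is thus estimated at 3% in this assay, within a range of -8% to 14%.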

Compound 3, a percentage reported as inhibition, at one concentration (the size of the read-out at that concentration, not a potency): 29%
Estimate against measurement, compound 3: 26 percentage points below, and the stated range ends below it.
By their numbers in this assay, from the lowest: compounds 2 and 1 (each within the scatter of the next); then compound 3.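

Going by these compounds alone, at this aromatic carbon, meta to a fused ring and para to a fused ring, the exchange gives the only step in the set so far that can be read as a real change: in this assay the value lies a number 31 percentage points higher from compound 2 to compound 3 (beyond the scatter). The earlier compounds shown here showed only values near the zero line, whereas this step shows that the group on this carbon can move the read-out, although a single concentration gives the size of the inhibition and not a potency. Nothing measured here accounts for the step, which belongs to the exchange as a whole, since the amino nitrogen loses its methyl group and the phenyl ring gains a methoxy group in the same move.

The compounds shown leave open which of these two differences carries the step, and a plain phenylamino or a methyl(4-methoxyphenyl)amino group on this same carbon would separate them. They also leave open whether the 4-methoxy group itself matters, which a 4-ethoxy or 4-chloro group on the phenyl ring would begin to test.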